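Aryl variation on the shared aminothiophene ketone core

The source may hold more compounds than are shown below. What is called first, only, known or untested is meant among the compounds shown, and "the series" means these compounds.

Measured to date in a functional assay on CCRF-CEM cells (Homo sapiens) for antiproliferative activity; on this read-out lower numbers stand for stronger inhibition and higher numbers for weaker inhibition:
compound 1, `COc1cc(C(=O)c2sc(-c3ccc(Cl)cc3)cc2N)cc(OC)c1OC`, gives 70 nM
compound 2, `COc1cc(C(=O)c2sc(-c3ccc(Cl)c(Cl)c3)cc2N)cc(OC)c1OC`, gives 290 nM
compound 3, `CCOc1ccc(-c2cc(N)c(C(=O)c3cc(OC)c(OC)c(OC)c3)s2)cc1`, gives 270 nM

Compound 3 holds the second highest of the three numbers. Its gap to compound 2 is within the scatter (a 1.1-fold lower number from compound 2 to compound 3 (0.03 log units; within the scatter)), so the two cannot be told apart; against compound 1 the difference is real (a 3.9-fold higher number from compound 1 to compound 3 (0.59 log units; beyond the scatter)).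

Compound 4, `COc1cc(C(=O)c2sc(-c3ccncc3)cc2N)cc(OC)c1OC`, has not yet been run. It differs from compound 3 by pyridin-4-yl in place of 4-ethoxyphenyl on an aromatic carbon.

Among the compounds with values here, no measured pair exchanges an aryl group for pyridin-4-yl, so the bearing steps are indirect. Both changes on the aryl ring seen so far moved the number by a modest amount in the weaker direction relative to compound 1 (a 4.1-fold higher number from compound 1 to compound 2 (0.62 log units; beyond the scatter); a 3.9-fold higher number from compound 1 to compound 3 (0.59 log units; beyond the scatter)), while the swap of one substituted aryl for another left it unchanged (a 1.1-fold lower number from compound 2 to compound 3 (0.03 log units; within the scatter)). Taken together these suggest the aryl part shifts the read-out only modestly, so compound 4 is expected to stay near compound 3 with a step of a 1.5-fold lower number from compound 3 to compound 4 (0.18 log units; within the scatter), not beyond the scatter. Compound 4 is therefore estimated at 180 nM, with a range from 50 nM to 600 nM.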

Compound 4, half-maximal inhibitory concentration: 110 nM
The estimate for compound 4 lay 1.6-fold (0.21 log units) above the measured number, and the stated range covers the measured number.
By their numbers in this assay, from the lowest: compounds 1 and 4 (each within the scatter of the next); then compounds 3 and 2 (each within the scatter of the next).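

In this assay, within the data shown here, pyridin-4-yl at this position, next to the ring sulfur, gives the first change of aryl group that lowers the number relative to a substituted phenyl: a 2.5-fold lower number from compound 3 to compound 4 (0.39 log units; beyond the scatter) and a 2.6-fold lower number from compound 2 to compound 4 (0.42 log units; beyond the scatter), two steps of similar size from quite different starting groups. Against 4-chlorophenyl the same exchange gives a 1.6-fold higher number from compound 1 to compound 4 (0.20 log units; within the scatter), so compound 4 cannot be told apart from compound 1, and the position accepts an aromatic ring with one ring nitrogen as well as it accepts the best phenyl seen so far, while 4-ethoxyphenyl and 3,4-dichlorophenyl remain the two groups with the higher numbers. Nothing in the available data accounts for these steps, and they stand here as observations only.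

Still open, as far as these compounds go, is whether the place of the ring nitrogen matters, which pyridin-3-yl or pyridin-2-yl would address, and where plain unsubstituted phenyl falls relative to 4-chlorophenyl and pyridin-4-yl. Also open, from the compounds shown here alone, is whether a substituted pyridine, such as one carrying a methyl or an amino group, follows the phenyl series or the unsubstituted pyridin-4-yl result.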